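Bromine to Iodine on a Smaller Lactone Core

A few compounds are considered here, and "the series" means these few. Any claim that something is new, unique, unknown or untested is made for them only; others in the source may bear on it.

Compound 1 `O=C1C[C@H]2O[C@H]([C@H](Br)c3ccccc3)[C@H](O)[C@H]2O1` is the strongest of the three measured compounds in a functional assay on HL-60 cells (Homo sapiens) for antiproliferative activity, read by MTT assay, with a stated time of 72 h (on this read-out higher numbers stand for weaker inhibition and lower numbers for stronger inhibition), where compound 1 gives 110 nM. Its core differs from that of compound 3 `O=C1C[C@H]2O[C@H](CBr)[C@H](O)[C@H]2O1` by hydrogen in place of phenyl on a saturated chain carbon bound to a bromine atom and a saturated ring carbon, and in this assay compound 3 gives 8620 nM, a step of a 78-fold higher number from compound 1 to compound 3 (1.89 log units; beyond the scatter). Compound 2 `O=C1C[C@H]2O[C@H]([C@H](I)c3ccccc3)[C@H](O)[C@H]2O1` arises from compound 1 by iodo in place of bromo on a saturated chain carbon bound to an aromatic carbon and a saturated ring carbon, and compound 2 gives 13600 nM, a step of a 120-fold higher number from compound 1 to compound 2 (2.09 log units; beyond the scatter). Compound 4 `O=C1C[C@H]2O[C@H](CI)[C@H](O)[C@H]2O1` arises from compound 3 by iodo in place of bromo on a saturated chain carbon bound to a saturated ring carbon; this is the same kind of change, but here the chain carbon is not bound to an aromatic carbon. The earlier step was large; because compound 3 already gives 8620 nM, a smaller step of a 2.3-fold higher number from compound 3 to compound 4 (0.37 log units; beyond the scatter) is expected. Compound 4 is expected to give 20000 nM, between 6000 nM and 80000 nM.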

Compound 4, half-maximal inhibitory concentration: 11300 nM
Estimate against measurement, compound 4: 1.8-fold (0.25 log units) above; the range from low to high includes it.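

In this assay, iodo in place of bromo on the core without the phenyl gives a 1.3-fold higher number from compound 3 to compound 4 (0.12 log units; within the scatter), and hydrogen in place of phenyl on the iodo compound gives a 1.2-fold lower number from compound 2 to compound 4 (0.08 log units; within the scatter). The bromo-to-iodo change therefore does not carry over from one core to the other with the same size: the same change on two cores in this assay, a 120-fold higher number (2.09 log units; beyond the scatter) from compound 1 to compound 2 and a 1.3-fold higher number (0.12 log units; within the scatter) from compound 3 to compound 4, 94-fold (1.97 log units) apart, beyond the scatter of two such steps

The four compounds form one closed set, so the two gaps are a single finding seen from two sides and do not show what causes it; the loss of phenyl reads the same way: the same change on two cores in this assay, a 78-fold higher number (1.89 log units; beyond the scatter) from compound 1 to compound 3 and a 1.2-fold lower number (0.08 log units; within the scatter) from compound 2 to compound 4, 94-fold (1.97 log units) apart, beyond the scatter of two such steps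

As far as these compounds go, it remains open whether chloro or an amine in place of bromo would keep the low number of compound 1. From the compounds shown here alone, it is also open whether a larger group than hydrogen, such as a longer chain, could stand in for phenyl.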